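Aryl amide change on the free-hydroxyl core

The source may report more compounds than this note shows. Statements on the series, on what has been measured and on what is new or still open speak of the compounds shown alone.

Three compounds of the series carry measured values in a functional assay on THP-1 cells (Homo sapiens) for inhibition, read by ELISA, with stated times of 2 h and 48 h; a higher number here means a weaker inhibitor, a lower number a stronger inhibitor. Compound 1 `CCOC1=C(/C(C)=N/OCC(=O)Nc2cccc(F)c2)N(C)S(=O)(=O)c2ccccc21` gives only a limit of the assay, > 20000 nM. Compound 2 `CCOC1=C(/C(C)=N/OCC(=O)Nc2ccc(C(F)(F)F)cc2)N(C)S(=O)(=O)c2ccccc21` gives 16700 nM in this assay. Compound 3 `C/C(=N\OCC(=O)Nc1cccc(F)c1)C1=C(O)c2ccccc2S(=O)(=O)N1C` again gives only a limit, > 20000 nM. Compound 3 thus stands at the same limit as compound 1 (the limit of > 20000 nM in this assay, at which 2 of the 3 values shown sit), with no number to place it on the scale, and the step that the two limits leave unreadable from compound 1 to compound 3 cannot be read. For the measured compounds named here, the only measured change on the aryl amide is an at least 1.1-fold lower number from compound 1 to compound 2 (0.07 log units; that floor lies within the scatter), which stays within the scatter.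

Compound 4 `C/C(=N\OCC(=O)Nc1c(F)cccc1F)C1=C(O)c2ccccc2S(=O)(=O)N1C` differs from compound 3 by 2,6-difluorophenyl in place of 3-fluorophenyl on an amide-type nitrogen. Since an at least 1.1-fold lower number from compound 1 to compound 2 (0.07 log units; that floor lies within the scatter) stayed within the scatter, the step expected here is a step that the limit leaves unreadable from compound 3 to compound 4, none beyond the scatter. Compound 4 is expected most likely to return only a limit again in this assay. Compound 4 is estimated at 30000 nM, with a range from 10000 nM to 100000 nM.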

Compound 4, half-maximal inhibitory concentration: > 20000 nM
Compound 4: no number, only a limit; the forecaster's own chance of this, stated with the estimate: 80%; the middle value lies beyond the limit too.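

Compound 3 and compound 4 both return only a limit and no number, so the step between them cannot be read: the limit of > 20000 nM in this assay, at which 3 of the 4 values shown sit. Still open, as far as these compounds go, is whether 2,6-difluorophenyl in place of 3-fluorophenyl changes inhibition at all, and how far beyond that limit either compound lies.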